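The compounds below may be only part of what the source reports. "The series", "measured", "known", "first", "only" and "open" are said of these compounds alone.

In a functional assay on MCF7 cells (Homo sapiens) for antiproliferative activity, read by sulforhodamine B assay, with a stated time of 48 h (a higher number here means a weaker inhibitor of growth, a lower number a stronger inhibitor of growth), three compounds built on a common core have been measured. Compound 1 `CN1CCN(CCCNc2ccnc3cc(Cl)ccc23)CC1` gives 17100 nM, and compound 2 `CN1CCN(CCCNc2ccnc3cc(C(F)(F)F)ccc23)CC1` gives 30800 nM. The two differ in one place, (trifluoromethyl in place of chloro on an aromatic carbon), and that change made a step of a 1.8-fold higher number from compound 1 to compound 2 (0.26 log units; within the scatter). Compound 3 `FC(F)(F)c1ccc2c(NCCCN3CCN(c4ccnc5cc(Cl)ccc45)CC3)ccnc2c1` carries a different core, and the difference between the two cores is not broken down here; in this assay compound 3 gives 4600 nM. Going from compound 2 to compound 3 the step is a 6.7-fold lower number from compound 2 to compound 3 (0.83 log units; beyond the scatter). Among the three, compound 3 holds the lowest number, with compound 1 and compound 2 both beyond the scatter above it.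

Compound 4 `FC(F)(F)c1ccc2c(NCCCN3CCN(c4ccnc5cc(C(F)(F)F)ccc45)CC3)ccnc2c1` has not yet been measured. Going by the values given here, it differs from compound 3 by trifluoromethyl in place of chloro on an aromatic carbon, which is the same change, at the same place, as the one between compound 1 and compound 2. Since that earlier step, a 1.8-fold higher number from compound 1 to compound 2 (0.26 log units; within the scatter), stayed within the scatter, a step of similar size is expected here, so compound 4 is estimated to show a 1.5-fold higher number from compound 3 to compound 4 (0.18 log units; within the scatter) relative to compound 3. Because compound 3 sits at 4600 nM, compound 4 is expected to give about 7000 nM in this assay, most likely between 3000 nM and 16000 nM.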

Compound 4, concentration for 50% growth inhibition: 17200 nM
The estimate for compound 4 lay 2.5-fold (0.39 log units) below the measured number; measured number above the stated range.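

In this assay, trifluoromethyl in place of chloro on the core of compound 3 gave a 3.7-fold higher number from compound 3 to compound 4 (0.57 log units; beyond the scatter), a step beyond the scatter, whereas the earlier step on the other core stayed within it. That contrast should not be read as a real difference between the cores, as the two steps point the same way and their sizes cannot be told apart: the same change on two cores in this assay, a 1.8-fold higher number (0.26 log units; within the scatter) from compound 1 to compound 2 and a 3.7-fold higher number (0.57 log units; beyond the scatter) from compound 3 to compound 4, 2.1-fold (0.32 log units) apart, within the scatter of two such steps. Going by these compounds alone, this shows that, in these two pairs, the change carried from one core to the other without a detectable change in its effect on the number, but with only one pair per core, it does not show that the step has a fixed size or that it would hold on a further core.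

From the compounds shown here alone, whether a fluoro, a methoxy or a nitrile on the same aromatic carbon would move the number in the same way remains open, and so does whether the chloro-to-trifluoromethyl step would keep its direction and size with a longer chain joining the two parts of the molecule. Going by these compounds, how the step would behave in any other cell line also remains open.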